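Returning a Chlorophenyl Group: Forecast for Compound 4

A few compounds are considered here, and "the series" means these few. Any claim that something is new, unique, unknown or untested is made for them only; others in the source may bear on it.

Compound 1, `CN1CCN(c2nc(-c3cccc(Cl)c3)nc3[nH]cnc23)CC1`, in an assay on cells for displacement of a labelled ligand from adenosine receptor A3 (Homo sapiens), read by scintillation counting and radioligand binding, with a stated time of 180 min, tested at 10 uM (on this read-out higher numbers stand for more inhibition at the one concentration tested (going by the name of the read-out) and lower numbers for less inhibition), sits at the assay's limit of > 80%.
Compound 2, `CN1CCN(c2nc(-c3ccc(Cl)c(Cl)c3)nc3c2ncn3C)CC1`, gives 35.3%.
Compound 3, `CN1CCN(c2nc(-c3ccccc3O)nc3c2ncn3C)CC1`, gives 15.3%.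

Compound 3 stands lowest of the two plain numbers reported. For the measured compounds named here, the one measured step that bears on it is a number 20 percentage points lower from compound 2 to compound 3 (beyond the scatter), which accompanied 2-hydroxyphenyl in place of 3,4-dichlorophenyl on an aromatic carbon. Compound 4, `CN1CCN(c2nc(-c3cccc(Cl)c3)nc3c2ncn3C)CC1`, differs from compound 3 by 3-chlorophenyl in place of 2-hydroxyphenyl on an aromatic carbon. This change runs in the opposite sense to the measured step, bringing a chlorinated phenyl group back onto the same aromatic carbon. Going by the values given here, compound 1, which carries the same 3-chlorophenyl group on a core that differs elsewhere, sits at the limit of > 80% in this assay, at which 1 of the 3 values shown sits, but no single-point step connects it to the others, so it only hints that a chlorophenyl group is compatible with strong displacement. On the measured step alone, a rise of roughly the size seen between the dichlorophenyl and hydroxyphenyl compounds is expected, giving an estimated a number 22.7 percentage points higher from compound 3 to compound 4 (beyond the scatter). Compound 4 is therefore estimated at 38%, with a range from 18% to 62%.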

Compound 4, a percentage reported as inhibition, at one concentration (the size of the read-out at that concentration, not a potency): 38.3%
Compound 4: the middle estimate sits 0.3 percentage points below what was measured; low and high end bracket the measured number.
By their numbers in this assay, from the lowest: compound 3; then compounds 2 and 4 (each within the scatter of the next). At a limit, above all of these: compound 1.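

For the compounds shown here, on this assay, a number 23 percentage points higher from compound 3 to compound 4 (beyond the scatter), the first evidence at this aromatic carbon that a phenyl group bearing a single chlorine differs from 2-hydroxyphenyl. With hydrogen in place of chloro on the phenyl ring, a number 3 percentage points higher from compound 2 to compound 4 (within the scatter), so 3-chlorophenyl and 3,4-dichlorophenyl cannot be told apart here. Compound 1 is now tied to the series by one change, methyl in place of hydrogen on an aromatic nitrogen, a number at least 41.7 percentage points lower from compound 1 to compound 4 (beyond the scatter), and its value is a limit, not a number: the limit of > 80% in this assay, at which 1 of the 4 values shown sits.

The compounds shown do not separate the loss of the hydroxy group from the shift in where the phenyl ring is substituted. On these data alone, it also remains open how an amine on the phenyl ring, or a longer chain in place of the methyl on the aromatic nitrogen, would read in this assay.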